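This account rests on a few compounds, and the source may have more. Where it says the series, first, only, none or still open, it means among the compounds named here.

Compound 3 `O=C(NOCc1ccccc1)c1cn(-c2ccccc2)nc1-c1ccc(Cl)cc1` carries a chloro on an aromatic carbon where compound 1 `O=C(NOCc1ccccc1)c1cn(-c2ccccc2)nc1-c1ccccc1` carries hydrogen. In a functional assay on MCF7 cells (Homo sapiens) for antiproliferative activity, read by MTT assay, with a stated time of 48 h, in the presence of a further agent that is not named here (a higher number here means a weaker inhibitor of growth, a lower number a stronger inhibitor of growth), compound 3 gives 10800 nM, the second highest of the three numbers seen so far. Compound 1 gives 13400 nM, and the step of a 1.2-fold lower number from compound 1 to compound 3 (0.09 log units; within the scatter) lies within the scatter. Compound 2 `Cc1ccc(-c2nn(-c3ccccc3)cc2C(=O)NOCc2ccccc2)cc1`, with methyl on that same aromatic carbon, gives 1870 nM; the steps of a 7.2-fold lower number from compound 1 to compound 2 (0.86 log units; beyond the scatter) and a 5.8-fold higher number from compound 2 to compound 3 (0.76 log units; beyond the scatter) both lie beyond the scatter, though each is modest.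

Compound 4 `O=C(NOCc1ccccc1)c1cn(-c2ccccc2)nc1-c1ccc(F)cc1` differs from compound 3 by fluoro in place of chloro on an aromatic carbon. Within the data shown here, no measured step exchanges one halogen for another. The step that bears most directly on this position is a 1.2-fold lower number from compound 1 to compound 3 (0.09 log units; within the scatter), which shows hydrogen and chloro giving numbers within the scatter of each other; the methyl steps show that only a modest move has been seen here at all. On that basis a change from chloro to fluoro is expected to give no step beyond the scatter in this assay. The estimated step is a 1.0-fold higher number from compound 3 to compound 4 (0.01 log units; within the scatter). Compound 4 is therefore expected to give about 11000 nM, within a range from 5000 nM to 25000 nM.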

Compound 4, concentration for 50% growth inhibition: 15300 nM
The estimate for compound 4 lay 1.4-fold (0.14 log units) below the measured number, within the range that was stated.
By their numbers in this assay, from the lowest: compound 2; then compounds 3, 1 and 4 (each within the scatter of the next).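

In this assay the change from 4-chlorophenyl to 4-fluorophenyl gives a 1.4-fold higher number from compound 3 to compound 4 (0.15 log units; within the scatter) and so shows that an exchange of one halogen for the other, on the aromatic carbon para to a large group, does not separate compound 3 from compound 4. Fluoro in place of hydrogen gives a 1.1-fold higher number from compound 1 to compound 4 (0.06 log units; within the scatter) and puts hydrogen, chloro and fluoro together at this place, while fluoro in place of methyl gives an 8.2-fold higher number from compound 2 to compound 4 (0.91 log units; beyond the scatter) and leaves compound 2 as the only member of the series set apart from the others, now by a step beyond the scatter to each of them. Nothing available for these compounds accounts for methyl alone standing apart from hydrogen and the two halogens.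

Going by these compounds, it remains open whether the lower number of compound 2 belongs to methyl alone or extends to an ethyl, methoxy or trifluoromethyl group on the same carbon. Also open, on these data alone, is how an amine or a carboxylic acid would behave at this place, and whether the gap between methyl and the other three groups survives a change elsewhere on the shared core.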